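Triazole aromatase series: hexyl to phenoxy swap

A few compounds are considered here, and "the series" means these few. Any claim that something is new, unique, unknown or untested is made for them only; others in the source may bear on it.

Compound 1 `CCCCCCCc1cn(C(c2ccccc2)c2ccccc2)nn1` and compound 2 `c1ccc(OCc2cn(C(c3ccccc3)c3ccccc3)nn2)cc1` share a core and differ in one change, (phenoxy in place of hexyl on a saturated chain carbon bound to an aromatic carbon). In an assay on isolated protein for inhibition of Aromatase (Homo sapiens), read by fluorescence and colorimetric assay, with a stated time of 30 min (on this read-out lower numbers stand for stronger inhibition and higher numbers for weaker inhibition), compound 1 gives 19400 nM and compound 2 gives 31300 nM; the step of a 1.6-fold higher number from compound 1 to compound 2 (0.21 log units; within the scatter) lies within the scatter, so the two values are read as equivalent.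

Compound 3 `CCCCCCCc1cn(Cc2ccc(C#N)cc2)nn1` carries a different core; the difference between the core of compound 3 and the core of compound 1 is not broken down here. In this assay compound 3 gives 3070 nM, the lowest of the three numbers, with compound 1 a step beyond the scatter away and compound 2 further still.

Compound 4 `N#Cc1ccc(Cn2cc(COc3ccccc3)nn2)cc1` is not yet measured. It stands to compound 3 as compound 2 stands to compound 1: the change is phenoxy in place of hexyl on a saturated chain carbon bound to an aromatic carbon, the same change as phenoxy in place of hexyl on a saturated chain carbon bound to an aromatic carbon, at the same place. Among the compounds with values here, the one measured instance of this change moved the number by a 1.6-fold higher number from compound 1 to compound 2 (0.21 log units; within the scatter), within the scatter, so the step of a 1.6-fold higher number from compound 3 to compound 4 (0.20 log units; within the scatter) is expected to be of similar size, small and toward a higher number. On that basis compound 4 is expected to give about 4900 nM in this assay, with a likely range from 2400 nM to 10000 nM.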

Compound 4, half-maximal inhibitory concentration: 6090 nM
Beside the measured number, compound 4's estimate is 1.2-fold (0.09 log units) below it; measured number inside the range.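

In this assay, phenoxy in place of hexyl gives a 2.0-fold higher number from compound 3 to compound 4 (0.30 log units; within the scatter), so on the core of compound 3 the two values are read as equivalent. Set beside the earlier step on the core of compound 1, the change carries from one core to the other with no difference that can be told apart: the same change on two cores in this assay, a 1.6-fold higher number (0.21 log units; within the scatter) from compound 1 to compound 2 and a 2.0-fold higher number (0.30 log units; within the scatter) from compound 3 to compound 4, 1.2-fold (0.09 log units) apart, within the scatter of two such steps. This rests on two pairs on two cores, with both steps inside the scatter; it shows that the swap left the number within the scatter on both cores, but it does not show a real effect of the change on either core, nor that the same would hold on a third core.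

Open, going by these compounds, is whether an amine, a carboxylic acid or a chain longer than hexyl, on the same saturated chain carbon, would move the number beyond the scatter. Also open, on these data alone, is how much of the gap between the cores belongs to the nitrile, which a plain benzyl group on the triazole nitrogen would help to settle.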